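This account rests on a few compounds, and the source may have more. Where it says the series, first, only, none or still open, it means among the compounds named here.

In a physicochemical assay for solubility, read by HPLC, in phosphate buffer, measured as kinetic solubility, at pH 7.4 (on this read-out higher numbers stand for higher solubility and lower numbers for lower solubility), compound 1 (`CCC(=O)c1cc(-c2ccc(Cl)cc2)n(-c2ccc(S(N)(=O)=O)cc2)c1`) gives 19500 nM and compound 2 (`CCOC(=O)c1cc(-c2ccc(Cl)cc2)n(-c2ccc(S(N)(=O)=O)cc2)c1C`) gives 4200 nM. Compound 2 therefore holds the lower of the two numbers, by a gap beyond the usual scatter. Compound 3 (`CCOC(=O)c1cc(-c2ccc(Cl)cc2)n(-c2ccc(S(N)(=O)=O)cc2)c1`) changes compound 2 in one place: hydrogen in place of methyl on an aromatic carbon. Going by the values given here, no measured pair shows this change alone. Compound 1 also carries hydrogen on that carbon and reads 19500 nM, though it differs in another group too. A moderate rise is expected, an estimated step of a 2.0-fold higher number from compound 2 to compound 3 (0.31 log units; beyond the scatter) in this assay. For compound 3 the estimated value is 8500 nM, with an expected range from 3500 nM to 20000 nM.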

Compound 3, solubility: 10800 nM
Beside the measured number, compound 3's estimate is 1.3-fold (0.10 log units) below it; measured number inside the range.
By their numbers in this assay, from the lowest: compound 2; then compounds 3 and 1 (each within the scatter of the next).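

In this assay, going by these compounds alone, hydrogen in place of methyl on this aromatic carbon gives a 2.6-fold higher number from compound 2 to compound 3 (0.41 log units; beyond the scatter), which is the first reading of this change alone, with the ethoxycarbonyl group kept in place. Ethoxy in place of ethyl on the carbonyl carbon gives a 1.8-fold lower number from compound 1 to compound 3 (0.26 log units; within the scatter), so that swap cannot be told apart from no difference here. Nothing at hand explains either step.

On these data alone, whether removing the methyl gives a similar step with ethyl on the carbonyl carbon remains open. So does what a longer chain or an amine on this aromatic carbon would read.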